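Amide nitrogen substituent swap in the thiophene aryloxyacetamide series

This account rests on a few compounds, and the source may have more. Where it says the series, first, only, none or still open, it means among the compounds named here.

Working notes on the thiophene-containing aryloxyacetamides. Within the data shown here, compound 2 `Cc1ccc(OCC(=O)N(Cc2cccs2)c2ccncc2)cc1` gives 52 nM in an assay on HEK293 cells for agonist activity at transient receptor potential cation channel subfamily M member 8 (Homo sapiens), read by fluorescence and calcium flux, with a stated time of 15 min (a lower number here means that less compound is needed, a higher number that more compound is needed for the effect), the lowest of the three numbers so far. Its nearest neighbour is compound 3 `CCN(Cc1cccs1)C(=O)COc1ccc(OC)cc1`, which gives 120 nM; the furthest is compound 1 `CCCc1ccc(OCC(=O)N(CC)Cc2cccs2)cc1`, which gives 1810 nM. Among the measured compounds shown here, the only single-point step measured so far is a 15-fold lower number from compound 1 to compound 3 (1.18 log units; beyond the scatter), a change on the aromatic ring of the aryloxy part, not on the amide nitrogen.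

The next compound, compound 4 `Cc1ccc(OCC(=O)N(Cc2cccs2)c2ccon2)cc1`, keeps the aryloxy part of compound 2 and changes the amide nitrogen substituent: 1,2-oxazol-3-yl in place of pyridin-4-yl on an amide-type nitrogen. For the measured compounds named here, no measured step touches this position in a matched way. Going by the values given here, compounds 1 and 3 carry a saturated chain on the amide nitrogen and compound 2 carries an aromatic ring there, but those pairs also differ on the aromatic ring, so their values alone show only that an aromatic group on the nitrogen is compatible with a low number. Among the compounds with values here, with no direct precedent, the change from one aromatic ring to another on the amide nitrogen is expected to give a step of a 1.9-fold higher number from compound 2 to compound 4 (0.28 log units; within the scatter), staying near the scatter or modestly beyond it. Compound 4 is therefore estimated at 100 nM in this assay, with a range from 30 nM to 400 nM.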

Compound 4, half-maximal effective concentration: 2 nM
Estimate against measurement, compound 4: 50-fold (1.70 log units) above; the measured number lies below the stated range.
By their numbers in this assay, from the lowest: compound 4; then compound 2; then compound 3; then compound 1.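

In this assay, the amide-type nitrogen turns out to be a position where exchanging one aromatic ring for another has a large effect: 1,2-oxazol-3-yl in place of pyridin-4-yl gives a 26-fold lower number from compound 2 to compound 4 (1.41 log units; beyond the scatter). Among these compounds, the earlier compounds showed only that an aromatic group on this nitrogen is compatible with a low number, whereas this matched pair shows that the identity of the ring matters, with the five-membered aromatic ring with 2 hetero atoms giving the lower number here. No supporting data bear on why this step is so large, so the result remains an observation on one pair.

The compounds shown leave open which difference between the two rings goes with the step, whether ring size, the number of hetero atoms or the number of hydrogen-bond acceptors, and a phenyl ring or a 1,3-thiazol-2-yl ring on the same nitrogen would help separate these. They also leave open whether the low number of the 1,2-oxazol-3-yl compound holds when the aromatic ring of the aryloxy part carries a group other than the methyl of compound 4, such as a chloro or ethyl group.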